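The source may report more compounds than this note shows. Statements on the series, on what has been measured and on what is new or still open speak of the compounds shown alone.

Measured compounds:
- compound 1: `CCc1ccccc1C(=O)OC(CCN(C)C)c1ccc(Cl)cc1`, 1290 nM
- compound 2: `Cc1cc(Br)ccc1C(=O)OC(CCN(C)C)c1ccc(Cl)cc1`, 1070 nM

In an assay on NIH3T3 cells with Urotensin-2 receptor (Homo sapiens) as the target (on this read-out lower numbers stand for an effect already at smaller amounts and higher numbers for an effect only at larger amounts of compound), compound 1 gives 1290 nM, while compound 2 gives 1070 nM. Within the data shown here, the one measured step, a 1.2-fold lower number from compound 1 to compound 2 (0.08 log units; within the scatter), exchanges one aromatic ring for another on the carbonyl carbon and leaves the rest of the molecule untouched. Among the measured compounds shown here, of the two numbers so far, compound 2 has the lowest, but compound 1 sits within the scatter of it, so the two cannot be ranked.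

Compound 3, `Cc1ccccc1NC(=O)OC(CCN(C)C)c1ccc(Cl)cc1`, differs from compound 2 by (2-methylphenyl)amino in place of 4-bromo-2-methylphenyl on a carbonyl carbon. The ring that enters carries a methyl group as before, but it now reaches the carbonyl carbon through an amino group that brings one hydrogen-bond donor, and the bromine is gone. For the measured compounds named here, the measured step from compound 1 to compound 2 only concerns substituents on a ring attached directly to the carbonyl; no measured step shows what attaching a ring through an amino group does here. The direction of the change is therefore open. The expected step is a 1.4-fold higher number from compound 2 to compound 3 (0.15 log units; within the scatter), held to a wide range. Compound 3 is estimated to give 1500 nM, between 400 nM and 6000 nM.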

Compound 3, half-maximal effective concentration: 3890 nM
Compound 3: middle estimate off by 2.6-fold (0.41 log units), on the low side, within the range that was stated.
By their numbers in this assay, from the lowest: compounds 2 and 1 (each within the scatter of the next); then compound 3.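

In this assay, among these compounds, the result gives the first steps beyond the scatter at this place on the carbonyl carbon: a 3.6-fold higher number from compound 2 to compound 3 (0.56 log units; beyond the scatter) and a 3.0-fold higher number from compound 1 to compound 3 (0.48 log units; beyond the scatter) are both modest in size. The two rings attached directly to the carbonyl carbon, 2-ethylphenyl and 4-bromo-2-methylphenyl, stay within the scatter of each other, while (2-methylphenyl)amino, with its ring reached through an amino group and its one hydrogen-bond donor, stands apart from both on the side of higher numbers. Nothing measured here gives a reason for this difference.

On these data alone, it remains open how much of the difference belongs to the amino link itself, as compound 3 also has no bromine, unlike compound 2, and a methyl group rather than the ethyl group of compound 1. Also open, as far as these compounds go, is how a (4-bromo-2-methylphenyl)amino group, or a ring joined to the carbonyl carbon through a methylene group or an ether oxygen instead of the amino group, would compare with these three compounds.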